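The compounds below may be only part of what the source reports. "The series", "measured", "known", "first", "only" and "open" are said of these compounds alone.

Compound 3 `C=C1C(=O)O[C@H]2CC3=C[C@H](C/C(C)=C/[C@@H](OC(=O)CC4CCCCC4)[C@H]12)OC3=O` gives 2000 nM in a functional assay on NCI-H460 cells (Homo sapiens) for cytotoxicity, read by MTT assay, with a stated time of 48 h; a higher number here means a weaker inhibitor, a lower number a stronger inhibitor. Compound 1 `C=C1C(=O)O[C@H]2CC3=C[C@H](C/C(C)=C/[C@@H](OC(=O)c4ccc(C(C)=O)cc4)[C@H]12)OC3=O` gives 2200 nM, and the comparison is a 1.1-fold lower number from compound 1 to compound 3 (0.04 log units; within the scatter), so these two cannot be told apart. Compound 2 `C=C1C(=O)O[C@H]2CC3=C[C@H](C/C(C)=C/[C@@H](OC(=O)CCl)[C@H]12)OC3=O` reaches only a limit of the assay, > 10000 nM. Its gap to the others is clear: an at least 4.5-fold higher number from compound 1 to compound 2 (0.65 log units; beyond the scatter), and an at least 5.0-fold lower number from compound 2 to compound 3 (0.69 log units; beyond the scatter). All three share one core and differ only in the group on a carbonyl carbon.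

Compound 4 `C=C1C(=O)O[C@H]2CC3=C[C@H](C/C(C)=C/[C@@H](OC(=O)C45CCC(C)(C(=O)O4)C5(C)C)[C@H]12)OC3=O` changes that group again: a group of 11 heavy atoms (9 carbon, 2 oxygen; one five-membered non-aromatic ring of carbon only, one five-membered non-aromatic ring with 1 hetero atom) in place of a group of 7 heavy atoms (7 carbon; one six-membered non-aromatic ring of carbon only), on a carbonyl carbon. The new group contains rings, as the groups of compound 1 and compound 3 do, whereas the chloromethyl group of compound 2 does not. Two quite different ring-bearing groups gave matching results, as compound 3 shows with a 1.1-fold lower number from compound 1 to compound 3 (0.04 log units; within the scatter), so a large change in this assay is not expected here. The risk lies towards higher numbers, as compound 2 shows with an at least 5.0-fold lower number from compound 2 to compound 3 (0.69 log units; beyond the scatter). The expected size of the change is a 1.3-fold higher number from compound 3 to compound 4 (0.10 log units; within the scatter). For compound 4 the estimated value is 2500 nM, with an expected range of 1000 nM to 7000 nM.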

Compound 4, half-maximal inhibitory concentration: 2000 nM
Estimate against measurement, compound 4: 1.3-fold (0.10 log units) above; the range from low to high includes it.
By their numbers in this assay, from the lowest: compounds 3, 4 and 1 (each within the scatter of the next). At a limit, above all of these: compound 2.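

In this assay, the group of compound 4 brings hydrogen-bond acceptors where cyclohexylmethyl has none, yet the result holds, with no change at the digits printed from compound 3 to compound 4 (within the scatter) and a 1.1-fold lower number from compound 1 to compound 4 (0.04 log units; within the scatter), so three quite different ring-bearing groups on this carbonyl carbon now cannot be told apart. Chloromethyl, the only group shown without a ring, still stands apart, with an at least 5.0-fold lower number from compound 2 to compound 4 (0.69 log units; beyond the scatter). The value of compound 2 is a limit of the assay and not a number, so the full size of that gap cannot be read: the limit of > 10000 nM in this assay, at which 1 of the 4 values shown sits.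

The compounds shown do not separate the loss of a ring from the presence of chlorine, and a plain hexyl chain or a simple methyl group would be needed to tell these apart. Going by these compounds, how a group carrying an amine or a carboxylic acid would behave at this position also remains open.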